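A few compounds are considered here, and "the series" means these few. Any claim that something is new, unique, unknown or untested is made for them only; others in the source may bear on it.

Measured so far in a functional assay on MC-38 cells (Mus musculus) for antiproliferative activity, read by CCK-8 assay, with a stated time of 48 h; a lower number here means a stronger inhibitor, a higher number a weaker inhibitor:
compound 1 `COc1ccc(/C=C\c2cc(OC)c(OC)c(OC)c2)cc1OCc1ccc(CNC(C)(C)C(=O)O)cc1`: > 10000 nM
compound 2 `COc1ccc(/C=C\c2cc(OC)c(OC)c(OC)c2)cc1OCc1ccc(CN2C[C@H](O)C[C@@H]2C(=O)O)cc1`: > 10000 nM
compound 3 `COc1ccc(/C=C\c2cc(OC)c(OC)c(OC)c2)cc1OCc1ccc(CN2CC[C@H](O)C2)cc1`: 7200 nM

Compound 1 stands only at a limit of this assay, with no number of its own. Compound 2 likewise sits at a limit. Compound 3 is the only one of the three with a read number. The step from compound 1 to compound 2 is a step that the two limits leave unreadable from compound 1 to compound 2. The step from compound 1 to compound 3 is an at least 1.3-fold lower number from compound 1 to compound 3 (0.14 log units; that floor lies within the scatter), and that from compound 2 to compound 3 is an at least 1.3-fold lower number from compound 2 to compound 3 (0.14 log units; that floor lies within the scatter); both carry floors that lie within the scatter, so neither establishes a real gain. the limit of > 10000 nM in this assay, at which 2 of the 3 values shown sit, sets the frame for what the series has shown so far.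

Compound 4 `COc1ccc(/C=C\c2cc(OC)c(OC)c(OC)c2)cc1OCc1ccc(CN2CC[C@@H](O)C2)cc1` differs from compound 1 by 3-hydroxypyrrolidin-1-yl in place of (1-carboxy-1-methylethyl)amino on a saturated chain carbon bound to an aromatic carbon. For the measured compounds named here, it carries the same 3-hydroxypyrrolidin-1-yl group as compound 3, with the opposite configuration at the defined stereocentre; no step between compound 3 and compound 4 is available. Going by the values given here, the step from compound 1 to compound 3 is the only measured change of the same kind, and it reads as a floor within the scatter, so no step beyond the scatter is expected in this assay. Compound 4 is estimated at 8000 nM, within 3000 nM to 20000 nM, close to the number given by compound 3. The expected step is an at least 1.2-fold lower number from compound 1 to compound 4 (0.09 log units; that floor lies within the scatter), with a real chance that only a limit is reported.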

Compound 4, half-maximal inhibitory concentration: 6900 nM
Beside the measured number, compound 4's estimate is 1.2-fold (0.06 log units) above it, within the range that was stated.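

In this assay, for the compounds shown here, the first comparison of configuration at this place gives a 1.0-fold lower number from compound 3 to compound 4 (0.02 log units; within the scatter), so the drawn configuration of the 3-hydroxypyrrolidin-1-yl group on the saturated chain carbon bound to an aromatic carbon leaves the reading unchanged within the scatter, and this pair is a direct comparison for that reason: the fact that compounds 3 and 4 differ only in the configuration as drawn. The second enantiomer also repeats the earlier picture for the exchange of (1-carboxy-1-methylethyl)amino, with an at least 1.4-fold lower number from compound 1 to compound 4 (0.16 log units; that floor lies within the scatter). Hydrogen in place of carboxy on a saturated ring carbon gives an at least 1.4-fold lower number from compound 2 to compound 4 (0.16 log units; that floor lies within the scatter), so neither floor establishes a real gain, and both hydroxypyrrolidine isomers stay weak in the same range.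

The reading of the two carboxy compounds against each other remains out of reach, and the comparisons with them have only floors to go on: the limit of > 10000 nM in this assay, at which 2 of the 4 values shown sit. Going by these compounds, whether the hydroxy group matters at all at this place remains open, as does whether an unsubstituted pyrrolidin-1-yl, a morpholin-4-yl or a dimethylamino group on the same saturated chain carbon would move the number beyond the scatter.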